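Aryl swap on the piperazine of a fused thiazole amide

A few compounds are considered here, and "the series" means these few. Any claim that something is new, unique, unknown or untested is made for them only; others in the source may bear on it.

Compound 1 `O=C(CN1CCN(c2ccncc2)CC1)Nc1nc2c(s1)CCCC2` is the weaker of the two measured entries in an assay on isolated protein for inhibition of long-chain fatty acid transport protein 1 (Homo sapiens), read by scintillation counting, with a stated time of 20 min; on this read-out higher numbers stand for weaker inhibition and lower numbers for stronger inhibition: in this assay compound 1 gives only > 1000 nM, which is a limit rather than a number (the limit of > 1000 nM in this assay, at which 1 of the 2 values shown sits). Compound 2 `O=C(CN1CCN(c2ccc(F)cc2)CC1)Nc1nc2c(s1)CCC2` in this assay gives 490 nM. Compound 3 `O=C(CN1CCN(c2ccc(F)cc2)CC1)Nc1nc2c(s1)CCCC2` is not yet measured; it differs from compound 1 by 4-fluorophenyl in place of pyridin-4-yl on an amine nitrogen in a ring. Going by the values given here, no measured step covers this pair. Compound 2 carries the same 4-fluorophenyl group and in this assay gives a numeric value 490 nM. On that basis compound 3 is expected to move out of the limit region, with an estimated step of an at least 2.0-fold lower number from compound 1 to compound 3 (0.30 log units; that floor lies within the scatter). Compound 3 is estimated at 500 nM, expected between 200 nM and 1500 nM.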

Compound 3, half-maximal inhibitory concentration: 77 nM
Compound 3: the middle estimate sits 6.5-fold (0.81 log units) above what was measured; the measured number lies below the stated range.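

In this assay, the group on this amine nitrogen in a ring strongly affects the read-out: with the rest of the core unchanged, 4-fluorophenyl in place of pyridin-4-yl gives an at least 12-fold lower number from compound 1 to compound 3 (1.11 log units; beyond the scatter). That step is a floor and not a full size, because the value of compound 1 is a limit: the limit of > 1000 nM in this assay, at which 1 of the 3 values shown sits.

Still open, on these data alone, is whether the fluorine or the carbon-only aromatic ring accounts for the step. Plain phenyl, 4-chlorophenyl and 4-methoxyphenyl on the same nitrogen would help separate the two.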